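This account rests on a few compounds, and the source may have more. Where it says the series, first, only, none or still open, it means among the compounds named here.

Values measured so far in a physicochemical assay for lipophilicity, at pH 7.4 (on this read-out lower numbers stand for lower lipophilicity and higher numbers for higher lipophilicity), are these:
Compound 1 `Cc1cc(C(=O)NCc2ccccn2)nn1Cc1cc(Cl)ccc1OCc1ccccc1` gives > 3.7 as a limit
Compound 2 `Cc1cc(C(=O)NCc2ccncc2)nn1Cc1cc(Cl)ccc1OCc1ccccc1` gives > 3.7 as a limit
Compound 3 `CC(=O)Nc1cc(C)n(Cc2cc(Cl)ccc2OCc2ccccc2)n1` gives > 3.7 as a limit

Compound 3 stands at > 3.7 and this is a limit, not a number. The series offers no other kind of reading so far, with the limit of > 3.7 in this assay, at which 3 of the 3 values shown sit, as the whole picture.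

The next step leads to compound 4 `Cc1cc(NC(=O)C(C)C)nn1Cc1cc(Cl)ccc1OCc1ccccc1` with isopropyl in place of methyl on a carbonyl carbon as the counted difference: isopropyl in place of methyl on a carbonyl carbon whose other neighbour is an amide-type nitrogen.

The measured steps that bear on this are a step that the two limits leave unreadable from compound 1 to compound 3 and a step that the two limits leave unreadable from compound 2 to compound 3 as the two ending at compound 3, with a step that the two limits leave unreadable from compound 1 to compound 2 as the third. None has a readable size, so none sets a scale for the change.

The expectation therefore rests on the structural change alone, starting from compound 3 with its limit of > 3.7 as the only anchor. The step expected in this assay is upward and is estimated as a step that the limit leaves unreadable from compound 3 to compound 4 with wide uncertainty on either side. For compound 4 the estimate is 4.5 with an expected range from 3.8 to 5.2 and a report as a limit is the likelier outcome.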

Compound 4, distribution coefficient: > 3.7
Compound 4: only a limit was reported; the forecaster's own chance of this, stated with the estimate: 90%; the middle value lies beyond the limit too.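

In this assay compound 4 gives > 3.7, which is a limit and not a number. The steps to compound 4 from compound 1, compound 2 and compound 3 therefore cannot be read, as all readings are the same limit: the limit of > 3.7 in this assay, at which 4 of the 4 values shown sit.

The compounds shown leave open how far any of them lies past that limit, and whether isopropyl in place of methyl shifts the read-out at all.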